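Swapping a Fluorinated Aryl Ring for a Methoxy One

The compounds below may be only part of what the source reports. "The series", "measured", "known", "first", "only" and "open" are said of these compounds alone.

Compound 2 `N#Cc1c(N2CCC(c3ccc(F)cc3)CC2)ccn(CC2CC2)c1=O` stands lowest of the two numbers measured in a functional assay on CHO cells for positive allosteric modulation of metabotropic glutamate receptor 2 (Homo sapiens), with a stated time of 30 min (on this read-out higher numbers stand for larger maximal responses and lower numbers for smaller maximal responses), where compound 2 gives 258%. Compound 1 `N#Cc1c(N2CCC(c3ccccc3)CC2)ccn(CC2CC2)c1=O` gives 309% in this assay. For the measured compounds named here, the only measured step, a number 51 percentage points lower from compound 1 to compound 2 (beyond the scatter), touches the same aryl ring that is altered here. Compound 3 `COc1ccccc1C1CCN(c2ccn(CC3CC3)c(=O)c2C#N)CC1` carries 2-methoxyphenyl in place of 4-fluorophenyl on a saturated ring carbon. That step supports some recovery when the fluorine leaves, but no measurement tells what the 2-methoxyphenyl adds, so the expectation is wide. Compound 3 is expected to reach 280%, within 200% to 360%, an expected step of a number 22 percentage points higher from compound 2 to compound 3 (beyond the scatter).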

Compound 3, largest response reached (Emax), in percent of the reference or control that the assay uses: 265%
The estimate for compound 3 lay 15 percentage points above the measured number; the measured number falls inside the stated range.
By their numbers in this assay, from the lowest: compounds 2 and 3 (each within the scatter of the next); then compound 1.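

In this assay, exchanging the 4-fluorophenyl for 2-methoxyphenyl on this saturated ring carbon leaves the maximal response unresolved (a number 7 percentage points higher from compound 2 to compound 3 (within the scatter)). Against the unsubstituted phenyl ring, methoxy in place of hydrogen also lowers the response (a number 44 percentage points lower from compound 1 to compound 3 (beyond the scatter)), so a lower maximal response now appears with two different aryl substituents, compounds 2 and 3. Nothing available explains this shared lowering. Still open, going by these compounds, is whether an amine or a carboxylic acid on the aryl ring would follow compounds 2 and 3 or stay level with compound 1.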